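This account rests on a few compounds, and the source may have more. Where it says the series, first, only, none or still open, it means among the compounds named here.

Measured so far:
compound 1 `CCCN(C)c1cc(C)nc2c(-c3ccc(Cl)cc3Cl)nn(C)c12`, in an assay on HEK293 cells for displacement of a labelled ligand from corticotropin-releasing factor receptor 1 (Homo sapiens) (on this read-out higher numbers stand for weaker inhibition and lower numbers for stronger inhibition), giving 24 nM;
compound 2 `CCCN(CC1CC1)c1cc(C)nc2c(-c3ccc(Cl)cc3Cl)nn(C)c12`, in this assay giving 1.7 nM.

Compound 2 stands lowest of the two numbers shown; compound 1 is the only neighbour, reached by a 14-fold lower number from compound 1 to compound 2 (1.15 log units; beyond the scatter) in reverse. Compound 3 `CCN(CCCOC)c1cc(C)nc2c(-c3ccc(Cl)cc3Cl)nn(C)c12` carries ethyl(3-methoxypropyl)amino in place of (cyclopropylmethyl)(propyl)amino on an aromatic carbon. For the measured compounds named here, the one step that bears on this is a 14-fold lower number from compound 1 to compound 2 (1.15 log units; beyond the scatter), where cyclopropyl entered the chain on this nitrogen; compound 3 has no ring there, so the expected direction is back toward the number of compound 1, though the remaining chains differ and the ether is untested. The expected step is a 5.3-fold higher number from compound 2 to compound 3 (0.72 log units; beyond the scatter). Compound 3 is estimated at 9 nM, range 3 nM to 30 nM.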

Compound 3, inhibition constant: 12.5 nM
Estimate against measurement, compound 3: 1.4-fold (0.14 log units) below; low and high end bracket the measured number.
By their numbers in this assay, from the lowest: compound 2; then compounds 3 and 1 (each within the scatter of the next).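

In this assay, ethyl(3-methoxypropyl)amino on this aromatic carbon, in place of (cyclopropylmethyl)(propyl)amino, gives a 7.4-fold higher number from compound 2 to compound 3 (0.87 log units; beyond the scatter) with the heavy-atom count unchanged and the three-membered ring gone. In place of methyl(propyl)amino it gives a 1.9-fold lower number from compound 1 to compound 3 (0.28 log units; within the scatter), so the ether chain and that smaller amino group stand level, and only compound 2 stands apart. Nothing measured here accounts for this gap.

From the compounds shown here alone, whether the gap follows the ring itself or the whole amino group stays open. Also open, going by these compounds, is how cyclobutylmethyl, or a hydroxyl at the end of the chain in place of the methoxy, would read here.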